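The compounds below may be only part of what the source reports. "The series", "measured", "known", "first", "only" and "open" are said of these compounds alone.

Measured in a functional assay on CNE-2 cells (Homo sapiens) for inhibition, read by MTT assay, with a stated time of 72 h; on this read-out higher numbers stand for weaker inhibition and lower numbers for stronger inhibition:
- compound 1 `Nc1nc2cc(-c3nn(CCCC(=O)NO)c4ncnc(N)c34)ccc2o1`: > 50000 nM (a limit)
- compound 2 `Nc1ncnc2c1c(-c1cnc3[nH]ccc3c1)nn2CCCCCCC(=O)NO`: 19500 nM
- compound 3 `Nc1ncnc2c1c(-c1cnc3[nH]ccc3c1)nn2CCC(=O)NO`: > 150000 nM (a limit)

Compound 1 gives > 50000 nM, which is a limit and not a number. Compound 4 `Nc1nc2cc(-c3nn(CC(=O)NO)c4ncnc(N)c34)ccc2o1` differs from compound 1 as follows: hydroxycarbamoyl in place of 2-(hydroxycarbamoyl)ethyl on a saturated chain carbon bound to an aromatic nitrogen. This places hydroxycarbamoyl where 2-(hydroxycarbamoyl)ethyl stood, so the chain becomes shorter. One measured step also shortens a chain at this kind of carbon, and it lies beyond the scatter: an at least 7.6-fold higher number from compound 2 to compound 3 (0.88 log units; beyond the scatter). On these data alone, its full size stays open, as it ends in a limit. A modest move toward a higher number in this assay is therefore expected, with the estimated step being a step that the limit leaves unreadable from compound 1 to compound 4. For compound 4 the estimate is 120000 nM, with an expected range of 50000 nM to 300000 nM.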

Compound 4, half-maximal inhibitory concentration: 12200 nM
Estimate against measurement, compound 4: 9.8-fold (0.99 log units) above; the measured number lies below the stated range.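

In this assay, shortening the chain on the saturated chain carbon bound to an aromatic nitrogen gives an at least 4.0-fold lower number from compound 1 to compound 4 (0.61 log units; beyond the scatter), whereas the earlier shortening gave an at least 7.6-fold higher number from compound 2 to compound 3 (0.88 log units; beyond the scatter). Shortening at this kind of carbon therefore has no single direction across the compounds shown, and the pair compound 1 and compound 4 goes against the earlier step. The full size of the new step stays open, as compound 1 stands at a limit: the limit of > 50000 nM in this assay, at which 1 of the 4 values shown sits.

The compounds shown leave open whether (hydroxycarbamoyl)methyl would give the same change on the core of compound 2. They also leave open whether a carboxylic acid in place of the hydroxycarbamoyl group would keep the number of compound 4.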